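The compounds below may be only part of what the source reports. "The series", "measured", "known", "first", "only" and "open" are said of these compounds alone.

Measured so far: compound 1 `O=C(NCc1ccc(S(=O)(=O)c2ccc(F)c(F)c2)cc1)c1cc2cnccc2[nH]1` gives 10 nM in an assay for inhibition of Nicotinamide phosphoribosyltransferase (Homo sapiens), read by mass spectrometry, with stated times of 15 min and 30 min; a higher number here means a weaker inhibitor, a lower number a stronger inhibitor; compound 2 `O=C(NCc1ccc(S(=O)(=O)c2ccc(F)cc2)cc1)c1cc2cnccc2[nH]1` gives 17 nM.

Compound 2 holds the higher of these two numbers, its nearest neighbour being compound 1, with a 1.7-fold higher number from compound 1 to compound 2 (0.23 log units; within the scatter). Compound 3 `Cc1ccccc1S(=O)(=O)c1ccc(CNC(=O)c2cc3cnccc3[nH]2)cc1` differs from compound 2 by 2-methylphenyl in place of 4-fluorophenyl on a sulfonyl sulfur. Within the data shown here, the only measured step, a 1.7-fold higher number from compound 1 to compound 2 (0.23 log units; within the scatter), concerns a change on the same aryl ring and stays within the scatter, but no step tests a swap of this kind, so compound 3 is expected to show only a modest step, a 1.8-fold higher number from compound 2 to compound 3 (0.25 log units; within the scatter), in this assay. Compound 3 is estimated at 30 nM, within 8 nM to 120 nM.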

Compound 3, half-maximal inhibitory concentration: 12 nM
Beside the measured number, compound 3's estimate is 2.5-fold (0.40 log units) above it; the measured number falls inside the stated range.
By their numbers in this assay, from the lowest: compounds 1, 3 and 2 (each within the scatter of the next).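

In this assay the change on the sulfonyl sulfur from 4-fluorophenyl to 2-methylphenyl gives a 1.4-fold lower number from compound 2 to compound 3 (0.15 log units; within the scatter) and the change from 3,4-difluorophenyl to 2-methylphenyl gives a 1.2-fold higher number from compound 1 to compound 3 (0.08 log units; within the scatter) so the aryl group here can lose all its fluorine and take a methyl group with no step beyond the scatter. The earlier pair had shown only the loss of one fluoro group. Nothing available explains this result. The compounds shown leave open whether a phenyl ring carrying an amine or a carboxylic acid would keep these numbers on the sulfonyl sulfur.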